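Extending the phosphate of a uridine monophosphate agonist

A few compounds are considered here, and "the series" means these few. Any claim that something is new, unique, unknown or untested is made for them only; others in the source may bear on it.

Compound 1, `CCSc1nc(=O)ccn1[C@@H]1O[C@H](COP(=O)(O)O)[C@@H](O)[C@H]1O`, in an in vitro functional assay on 1321-N1 cells for agonist activity at P2Y purinoceptor 2 (Homo sapiens), read by scintillation proximity assay and inositol phosphate accumulation (on this read-out higher numbers stand for an effect only at larger amounts of compound and lower numbers for an effect already at smaller amounts), gives 1500 nM.
Compound 2, `COc1nc(=O)ccn1[C@@H]1O[C@H](COP(=O)(O)O)[C@@H](O)[C@H]1O`, in this assay gives 9900 nM.

For the measured compounds named here, of the two compounds measured so far, compound 2 stands at the higher number; its nearest neighbour is compound 1, and the step of a 6.6-fold higher number from compound 1 to compound 2 (0.82 log units; beyond the scatter) separates them, where a methoxy stands in place of an ethylsulfanyl on an aromatic carbon.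

Compound 3, `COc1nc(=O)ccn1[C@@H]1O[C@H](COP(=O)(O)OP(=O)(O)O)[C@@H](O)[C@H]1O`, differs from compound 2 at a different site: a group of 4 heavy atoms (3 oxygen, 1 phosphorus; no ring) in place of a hydrogen atom, on an oxygen. No measured step bears directly on this change, since the only step shown concerns the substituent on the aromatic carbon and leaves the phosphate untouched. The size of the step in this assay therefore cannot be read from the measured compounds, and the direction rests on the structural change alone. The account expects compound 3 to move to a lower number than compound 2, a step of a 4.0-fold lower number from compound 2 to compound 3 (0.60 log units; beyond the scatter), with wide uncertainty. The expected value for compound 3 in this assay is 2500 nM, within a range from 300 nM to 20000 nM.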

Compound 3, half-maximal effective concentration: 907 nM
The estimate for compound 3 lay 2.8-fold (0.44 log units) above the measured number; the range from low to high includes it.
By their numbers in this assay, from the lowest: compounds 3 and 1 (each within the scatter of the next); then compound 2.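

The phosphate end of the molecule, left untouched by the earlier comparison, proves responsive in this assay: with the methoxy group held constant, placing a group of 4 heavy atoms (3 oxygen, 1 phosphorus; no ring) in place of a hydrogen atom, on an oxygen whose other neighbours are phosphorus, gives an 11-fold lower number from compound 2 to compound 3 (1.04 log units; beyond the scatter). Compound 3 therefore produces its effect at a smaller amount of compound than compound 2, and this large step runs in the opposite direction to the modest change seen at the aromatic carbon, a 6.6-fold higher number from compound 1 to compound 2 (0.82 log units; beyond the scatter). No measurement here accounts for the gain, and the reason for it remains unexplained.

The compounds shown leave open whether the same gain would appear with ethylsulfanyl on the aromatic carbon, since the extended phosphate is seen only with methoxy. They also leave open whether a longer chain at this oxygen, such as a triphosphate, would lower the number further or whether an amine on the aromatic carbon would be tolerated alongside the group now present.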